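Sulfoxide Series: Bromothiophene in Place of Hydroxymethylpyrimidine

The compounds below may be only part of what the source reports. "The series", "measured", "known", "first", "only" and "open" are said of these compounds alone.

Compound 1 `Cc1cc(O)nc(C[S+]([O-])C(c2ccccc2)c2ccccc2)n1` gives 109000 nM in an assay on HEK293 cells for inhibition of sodium-dependent dopamine transporter (Homo sapiens), read by scintillation counting, with stated times of 5 min and 1 min (on this read-out lower numbers stand for stronger inhibition and higher numbers for weaker inhibition), the higher of the two numbers reported, while compound 3 `[O-][S+](Cc1ccncc1)C(c1ccccc1)c1ccccc1` gives 63500 nM and compound 2 `COc1ccnc(C[S+]([O-])C(c2ccccc2)c2ccccc2)c1OC` gives "not active" (no number reported). Compound 4 `[O-][S+](Cc1ccsc1Br)C(c1ccccc1)c1ccccc1` differs from compound 1 by 2-bromothiophen-3-yl in place of 4-hydroxy-6-methylpyrimidin-2-yl on a saturated chain carbon bound to a sulfur. Going by the values given here, the only measured step that bears on this change is a 1.7-fold lower number from compound 1 to compound 3 (0.23 log units; within the scatter), which exchanged the same ring on the same chain carbon. Because that step was a 1.7-fold lower number from compound 1 to compound 3 (0.23 log units; within the scatter), another exchange of this ring is expected to stay within the scatter as well, in no foreseeable direction; compound 2, which returned no number, shows that a limit is possible. The expected step is a 1.3-fold lower number from compound 1 to compound 4 (0.11 log units; within the scatter). Compound 4 is therefore estimated at 85000 nM, in the range 25000 nM to 300000 nM.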

Compound 4, half-maximal inhibitory concentration: 29300 nM
The estimate for compound 4 lay 2.9-fold (0.46 log units) above the measured number; measured number inside the range.
By their numbers in this assay, from the lowest: compound 4; then compounds 3 and 1 (each within the scatter of the next).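

In this assay an exchange of the ring on a saturated chain carbon bound to a sulfur now goes beyond the scatter, which the earlier step did not: 2-bromothiophen-3-yl gives a 3.7-fold lower number from compound 1 to compound 4 (0.57 log units; beyond the scatter) and also a 2.2-fold lower number from compound 3 to compound 4 (0.34 log units; beyond the scatter) in this short series. This position therefore responds to the ring it carries, though both steps are modest. Nothing measured here accounts for the difference. As far as these compounds go, whether the bromine or the thiophene ring carries the step stays open. A thiophen-3-yl group without bromine on the same carbon would separate the two.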